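A New Side Group on the Core of Compound 3

The source may report more compounds than this note shows. Statements on the series, on what has been measured and on what is new or still open speak of the compounds shown alone.

Of the compounds shown here, three have been measured in a functional assay on the whole organism (strain albino) for inhibition, with Rattus norvegicus as the target, read by paw edema, with a stated time of 1 h, at a dose of 20 mmol/kg by the intraperitoneal route; on this read-out higher numbers stand for more inhibition at the one dose given (going by the name of the read-out) and lower numbers for less inhibition. Compound 1 `N#CC1=C(NCN2CCCC2)N(c2ccccc2)C(=O)N2CCCCC(N3CCCC3)C12` gives 22.9%, compound 2 `COc1ccc(N/C=N/C2=C(C#N)C3C(N4CCCC4)CCCCN3C(=O)N2c2ccccc2)cc1` gives 20.6%, and compound 3 `N#CC1=C(/N=C/c2ccccc2)N(c2ccccc2)C(=O)N2CCCCC(N3CCCC3)C12` gives 46.5%, the highest of the three numbers, with compound 1 nearest to it and compound 2 furthest. The step of a number 23.6 percentage points higher from compound 1 to compound 3 (beyond the scatter) and the step of a number 25.9 percentage points higher from compound 2 to compound 3 (beyond the scatter) both accompany the arrival of the group carrying the six-membered aromatic ring on the double-bonded ring carbon, while the step of a number 2.3 percentage points lower from compound 1 to compound 2 (within the scatter) lies within the scatter.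

Compound 4 `CCOC(=O)C(=O)NC1=C(C#N)C2C(N3CCCC3)CCCCN2C(=O)N1c1ccccc1` has not yet been measured. It differs from compound 3 in that (a group of 8 heavy atoms (4 carbon, 1 nitrogen, 3 oxygen; no ring) in place of a group of 8 heavy atoms (7 carbon, 1 nitrogen; one six-membered aromatic ring of carbon only), on a double-bonded ring carbon). Within the data shown here, the group that leaves is the one whose arrival went with the two upward steps, so a reversal of that kind of step is the nearest guide, although the entering group resembles neither the group on compound 1 nor the one on compound 2. Compound 4 is therefore expected to fall below compound 3 in this assay by an estimated a number 21.5 percentage points lower from compound 3 to compound 4 (beyond the scatter). The value of compound 4 in this assay is estimated at 25%, within a range from 10% to 42%.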

Compound 4, a percentage reported as inhibition, in the whole organism at one dose (the size of the read-out at that dose, not a potency): 71.2%
The estimate for compound 4 lay 46.2 percentage points below the measured number, and the stated range ends below it.
By their numbers in this assay, from the lowest: compounds 2 and 1 (each within the scatter of the next); then compound 3; then compound 4.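

In this assay, the ((ethoxycarbonyl)carbonyl)amino group on the double-bonded ring carbon gives a number 24.7 percentage points higher from compound 3 to compound 4 (beyond the scatter), so the six-membered aromatic ring of carbon only is not needed at this position for the highest number among the four compounds. The group without a ring also stands clear of the two amine-bearing side groups, with a number 50.6 percentage points higher from compound 2 to compound 4 (beyond the scatter) and a number 48.3 percentage points higher from compound 1 to compound 4 (beyond the scatter), and since it replaces the group of compound 3 at an equal heavy-atom count, that count does not separate these two compounds. No evidence is given on why this change goes with the higher number.

The compounds shown leave open which part of the new group carries the rise: the ethyl ester, the two carbonyls or the amide hydrogen. A carboxylic acid in place of the ethyl ester, or a longer chain on the ester oxygen, would begin to separate these parts.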